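The source may report more compounds than this note shows. Statements on the series, on what has been measured and on what is new or still open speak of the compounds shown alone.

Compound 1 `COc1ncc(-c2ccc3ncc(C(=O)N4CCC(O)CC4)n3c2)cc1NS(=O)(=O)c1ccc(F)cc1F` carries a (4-hydroxypiperidin-1-yl)carbonyl on its core; in a functional assay on MDA-MB-231 cells (Homo sapiens) for antiproliferative activity, read by sulforhodamine B assay, with a stated time of 72 h (a higher number here means a weaker inhibitor, a lower number a stronger inhibitor), compound 1 gives 630 nM, the higher of the two numbers recorded. Compound 2 `CCOC(=O)c1cc2cc(-c3cnc(OC)c(NS(=O)(=O)c4ccc(F)cc4)c3)ccc2[nH]1`, an ethoxycarbonyl on a different core, gives 150 nM in this assay, a gap from compound 1 that lies beyond the scatter. Compound 3 `CCOC(=O)c1cn2cc(-c3cnc(OC)c(NS(=O)(=O)c4ccc(F)cc4)c3)ccc2n1` reaches only a limit in this assay, > 20000 nM, an instance of the limit of > 20000 nM in this assay, at which 1 of the 3 values shown sits. Compound 4 `CCOC(=O)c1cnc2ccc(-c3cnc(OC)c(NS(=O)(=O)c4ccc(F)cc4F)c3)cn12` keeps the core of compound 1 and differs in one place: ethoxy in place of 4-hydroxypiperidin-1-yl on a carbonyl carbon. Within the data shown here, no measured pair shares this change, so the direction is uncertain; a modest loss is expected, as in a 1.9-fold higher number from compound 1 to compound 4 (0.28 log units; within the scatter). Compound 4 is therefore estimated at 1200 nM in this assay, between 250 nM and 6000 nM.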

Compound 4, half-maximal inhibitory concentration: 120 nM
Estimate against measurement, compound 4: 10-fold (1.00 log units) above; the measured number lies below the stated range.
By their numbers in this assay, from the lowest: compounds 4 and 2 (each within the scatter of the next); then compound 1. At a limit, above all of these: compound 3.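

In this assay, replacing 4-hydroxypiperidin-1-yl with ethoxy on this carbonyl carbon gives a 5.3-fold lower number from compound 1 to compound 4 (0.72 log units; beyond the scatter). On the core of compound 1, antiproliferative activity therefore does not depend on the piperidine ring or its hydrogen-bond donor, and this position accepts a change of group with a gain rather than a loss. Nothing in the data at hand accounts for this gain. The compounds shown leave open how a carboxylic acid, a dimethylamino group or a longer alkoxy chain on this carbonyl carbon would compare with ethoxy.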